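A few compounds are considered here, and "the series" means these few. Any claim that something is new, unique, unknown or untested is made for them only; others in the source may bear on it.

Of the compounds shown here, two have so far been measured in an assay on CHO-K1 cells for displacement of a labelled ligand from melanin-concentrating hormone receptor 1 (Homo sapiens), with a stated time of 2 h; a lower number here means a stronger inhibitor, a higher number a weaker inhibitor. Compound 1 `Cc1nc(N2CCN(C3CCOCC3)CC2)nc2ccc(NC(=O)COc3ccc(Cl)cc3)cc12` gives 45 nM in this assay. Compound 2 `Cc1nc(N2CCC(NC(=O)C(C)C)CC2)nc2ccc(NC(=O)COc3ccc(Cl)cc3)cc12`, which bears a different group on the saturated ring, gives 15 nM in this assay. Within the data shown here, compound 2 therefore holds the lowest of the two numbers; compound 1 is its only neighbour, and the gap between them lies beyond the usual scatter of repeated measurements.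

The next step leads to compound 3 `Cc1nc(N2CCC(C(=O)NC(C)C)CC2)nc2ccc(NC(=O)COc3ccc(Cl)cc3)cc12`, which has not yet been measured in this assay. The change from compound 2 to compound 3 is isopropylcarbamoyl in place of (isopropylcarbonyl)amino on a saturated ring carbon; the two compounds are built from the same atoms, joined differently. Among the measured compounds shown here, no pair of measured compounds shows a change of this kind, so there is no measured step to rest on. The step is expected to be small, most likely toward a somewhat higher number, though a result within the scatter would not surprise; a 2.0-fold higher number from compound 2 to compound 3 (0.30 log units; within the scatter) is the expected size and direction. For compound 3 the estimate in this assay is 30 nM, with a range from 9 nM to 100 nM.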

Compound 3, half-maximal inhibitory concentration in the melanin-concentrating hormone receptor 1 assay: 15 nM
Beside the measured number, compound 3's estimate is 2.0-fold (0.30 log units) above it; the measured number falls inside the stated range.
By their numbers in the melanin-concentrating hormone receptor 1 assay, from the lowest: compounds 2 and 3 (each within the scatter of the next); then compound 1.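

The two compounds are built from the same atoms, joined differently, and in the melanin-concentrating hormone receptor 1 assay the exchange of (isopropylcarbonyl)amino for isopropylcarbamoyl on this saturated ring carbon gives no change at the digits printed from compound 2 to compound 3 (within the scatter), so this assay does not distinguish the two ways of joining the amide to the ring. The earlier pair could not show this, since compound 1 and compound 2 differ by a different group at this place, whereas here the same exchange also gives, in a physicochemical assay for solubility, in phosphate buffer (on this read-out higher numbers stand for higher solubility and lower numbers for lower solubility), a 1.6-fold lower number from compound 2 to compound 3 (0.19 log units; within the scatter), with compound 2 at 205000 nM and compound 3 at 132000 nM in that read-out. No measured information offered here accounts for the absence of a clear difference in either assay.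

The compounds shown leave open whether a carboxylic acid or a primary amine on this saturated ring carbon, or a longer chain in place of the isopropyl group, would stay in the range of compound 2 and compound 3 in the melanin-concentrating hormone receptor 1 assay. Among these compounds, they also leave open how such groups would read in the physicochemical assay, where only this one exchange can be followed.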